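Growth inhibition of Lemna aequinoctialis: a methoxy added

The compounds below may be only part of what the source reports. "The series", "measured", "known", "first", "only" and "open" are said of these compounds alone.

Measured compounds:
compound 1 `COc1ccc(NC(=S)N/N=C2\C(=O)Nc3ccc([N+](=O)[O-])cc32)cc1` — 25%
compound 2 `O=C1Nc2ccc([N+](=O)[O-])cc2/C1=N/NC(=S)Nc1ccc(Br)cc1` — 20%

In a functional assay on the whole organism for inhibition, with Lemna aequinoctialis as the target, tested at 1000 ug/mL (a lower number here means less inhibition of growth, a higher number more inhibition of growth at the concentration tested), compound 1 gives 25%, and compound 2 gives 20%. Compound 1 stands highest of the two numbers shown, but its nearest neighbour is compound 2, and the step is a number 5 percentage points lower from compound 1 to compound 2 (within the scatter), so the two values cannot be told apart. Going by the values given here, that step, bromo in place of methoxy on an aromatic carbon, is the only measured change in the set.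

Compound 3 `COc1ccc(NC(=S)N/N=C2\C(=O)Nc3ccc([N+](=O)[O-])cc32)c(OC)c1` has not yet been measured in this assay. It differs from compound 1 by methoxy in place of hydrogen on an aromatic carbon. Among the compounds with values here, no measured step touches this position; the one step that exists, from compound 1 to compound 2, concerns a different group and stayed within the scatter. There is therefore no ground to expect a step beyond the scatter in either direction for compound 3.

The account accordingly expects compound 3 to give 25% in this assay, with a range from 8% to 45%. This estimate for compound 3 means a step of no change at the digits printed from compound 1 to compound 3 (within the scatter), which is expected to lie within the scatter.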

Compound 3, percent growth inhibition at one concentration: 30%
Compound 3: the middle estimate sits 5 percentage points below what was measured, and the stated range covers the measured number.
By their numbers in this assay, from the lowest: compounds 2, 1 and 3 (each within the scatter of the next).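

Going by these compounds alone, this position, on an aromatic carbon ortho to a large group and meta to a methoxy group, now has a measured step of its own, whereas the earlier compounds showed only bromo in place of the existing methoxy. In this assay methoxy in place of hydrogen gives a number 5 percentage points higher from compound 1 to compound 3 (within the scatter) and so hydrogen and methoxy cannot be told apart here at the concentration tested. No independent evidence bears on this result, and the step itself offers no account of what lies behind it.

The compounds shown leave open whether any other group at this position, such as an amine, a carboxylic acid or a longer chain like butoxy, would give a step beyond the scatter, since hydrogen and methoxy are the only two groups seen there. They also leave open whether methoxy at this position would read the same alongside bromo in place of the existing methoxy, as no compound shown carries both groups.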